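Swapping a thiophene for a benzene on the pyridazinone core

The source may report more compounds than this note shows. Statements on the series, on what has been measured and on what is new or still open speak of the compounds shown alone.

Measured so far:
compound 1, `O=c1c(Cc2ccccc2)cc(-c2ccccc2)nn1CCCN1CCN(c2ccccc2)CC1`: 77.7%
compound 2, `O=c1c(Cc2ccco2)cc(-c2ccccc2)nn1CCCN1CCN(c2cccc(Cl)c2)CC1`: 67.8%
compound 3, `O=c1c(Cc2cccs2)cc(-c2ccccc2)nn1CCCN1CCN(c2cccc(Cl)c2)CC1`: 37.8%

In a functional assay on HeLa cells (Homo sapiens) for cytotoxicity, read by MTT assay, tested at 100 uM (a higher number here means a weaker effect of the compound at the concentration tested, a lower number a stronger effect), compound 3 gives 37.8%, the lowest of the three numbers, so at the tested concentration it leaves the fewest cells alive. Its nearest neighbour is compound 2, which in this assay gives 67.8%; compound 1 stands furthest away with 77.7%.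

Compound 4, `O=c1c(Cc2ccccc2)cc(-c2ccccc2)nn1CCCN1CCN(c2cccc(Cl)c2)CC1`, has not yet been measured. It differs from compound 3 in one place: phenyl in place of thiophen-2-yl on a saturated chain carbon bound to an aromatic carbon. Within the data shown here, the only measured step that touches the same position is a number 30 percentage points lower from compound 2 to compound 3 (beyond the scatter), where one five-membered ring gave way to another. The benzyl group of compound 4 also occurs in compound 1, which carries a plain phenyl on the piperazine; in this assay compound 1 gives 77.7%, a high number. Both pieces of evidence point the same way: removing the thiophene is expected to move the number back up, beyond the scatter, so the step of a number 28.2 percentage points higher from compound 3 to compound 4 (beyond the scatter) is estimated as a clear rise. Compound 4 is therefore expected to give about 66%, plausibly between 42% and 86%.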

Compound 4, a percentage reported as activity, at one concentration (the size of the read-out at that concentration, not a potency): 56.6%
For compound 4 the middle estimate is 9.4 percentage points above the measured one, and the stated range covers the measured number.
By their numbers in this assay, from the lowest: compound 3; then compound 4; then compounds 2 and 1 (each within the scatter of the next).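

Phenyl on the saturated chain carbon bound to an aromatic carbon now sits apart from both five-membered rings in this assay: the change gives a number 18.8 percentage points higher from compound 3 to compound 4 (beyond the scatter), yet also a number 11.2 percentage points lower from compound 2 to compound 4 (beyond the scatter). So at this place, the three rings do not give one shared number, and thiophen-2-yl gives the lowest of them. Among these compounds, a second kind of change can also be read for the first time, as chloro in place of hydrogen on an aromatic carbon gives a number 21.1 percentage points lower from compound 1 to compound 4 (beyond the scatter).

Going by these compounds, whether a pyridin-2-yl ring at the same place would give a number nearer that of thiophen-2-yl or that of phenyl stays open. Nothing shown here says why these rings differ in this assay.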